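This account rests on a few compounds, and the source may have more. Where it says the series, first, only, none or still open, it means among the compounds named here.

Two compounds share one core and differ only in the group on a saturated chain carbon bound to a carbonyl carbon and an oxygen on a saturated carbon. Compound 1 `CC1(C[C@@H](O)C(=O)N2N=CC[C@H]2C(=O)NCc2cc(Cl)ccc2-n2cnnn2)CC1` carries a (1-methylcyclopropyl)methyl there and gives 730 nM in a functional assay on a cell-free system (plasma, Homo sapiens), with a stated time of 3 min; a lower number here means a stronger inhibitor, a higher number a weaker inhibitor. Compound 2 `Cc1cccc([C@@H](O)C(=O)N2N=CC[C@H]2C(=O)NCc2cc(Cl)ccc2-n2cnnn2)c1` carries a 3-methylphenyl instead and gives 830 nM in this assay. On these two numbers compound 2 has the higher one, but the gap to compound 1 is small: the step of a 1.1-fold higher number from compound 1 to compound 2 (0.06 log units; within the scatter) lies within the scatter, so the two cannot be told apart.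

Compound 3 `CC(C)(C)[C@@H](O)C(=O)N1N=CC[C@H]1C(=O)NCc1cc(Cl)ccc1-n1cnnn1` changes the same spot again: tert-butyl in place of 3-methylphenyl on a saturated chain carbon bound to a carbonyl carbon and an oxygen on a saturated carbon. Among the compounds with values here, the only measured step at this position, from a ring-containing chain to an aromatic ring, left the number essentially unchanged. Within the data shown here, that step is the sole guide here, and it suggests that this position tolerates quite different groups without a shift beyond the scatter. A tert-butyl is smaller than the 3-methylphenyl it replaces, but nothing measured shows that size alone matters here.

Compound 3 is therefore expected to sit near its neighbours, with the step of a 1.0-fold lower number from compound 2 to compound 3 (0.02 log units; within the scatter) estimated to fall within the scatter. The estimate for compound 3 in this assay is 800 nM, within a range from 350 nM to 1800 nM.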

Compound 3, half-maximal inhibitory concentration: 1400 nM
Compound 3: the middle estimate sits 1.8-fold (0.24 log units) below what was measured; low and high end bracket the measured number.
By their numbers in this assay, from the lowest: compounds 1, 2 and 3 (each within the scatter of the next).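

Within the data shown here, compound 3 is the first here with no ring at all on this saturated chain carbon, and its tert-butyl has 4 heavy atoms where the 3-methylphenyl has 7, yet in this assay this change gives a 1.7-fold higher number from compound 2 to compound 3 (0.23 log units; within the scatter), while the swap from the (1-methylcyclopropyl)methyl gives a 1.9-fold higher number from compound 1 to compound 3 (0.28 log units; within the scatter). The position therefore accepts an aromatic ring, a chain carrying a small ring and a branched group with no ring, and neither the presence of a ring nor the heavy-atom count separates these three compounds on the numbers shown. No measurement available here explains how these three groups are accommodated at this position.

As far as these compounds go, all three groups are built of carbon only, so the effect of an amine, a carboxylic acid or a longer chain in this place remains open. Among these compounds, also open is whether any group on this carbon can move the number beyond the scatter, and in which direction, since no step seen so far at this position does so.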